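The source may hold more compounds than are shown below. What is called first, only, known or untested is meant among the compounds shown, and "the series" means these compounds.

Measured so far:
compound 1 `CC(C)C(C#Cc1cccc(C(=O)NCc2ccccc2C(F)(F)F)c1)N(O)C(N)=O`: 500 nM
compound 2 `C[C@H](C#Cc1cccc(C(=O)NCCC(c2ccccc2)c2ccc(S(N)(=O)=O)cc2)c1)N(O)C(N)=O`: 1000 nM

In an assay for inhibition of Polyunsaturated fatty acid 5-lipoxygenase (Homo sapiens), read by HPLC, with stated times of 15 min and 10 min (on this read-out lower numbers stand for stronger inhibition and higher numbers for weaker inhibition), compound 1 gives 500 nM, the lowest of the two numbers in hand. Compound 2 gives 1000 nM in this assay, and the gap between the two lies within the usual scatter of repeated measurements, so they cannot be told apart on these numbers. Compound 3 `CC(C#Cc1cccc(C(=O)NCc2ccccc2C(F)(F)F)c1)N(O)C(N)=O` has not yet been measured. It differs from compound 1 in one place: methyl in place of isopropyl on a saturated chain carbon bound to an amide-type nitrogen and a triple-bonded carbon. Among the measured compounds shown here, no measured pair shows this exact change, so its effect is unknown from the data at hand; compound 2, which also has methyl rather than isopropyl in that place but a different amide side, gives 1000 nM, not far from compound 1. The expected step is small, a 1.6-fold higher number from compound 1 to compound 3 (0.20 log units; within the scatter), with no clear direction beyond the scatter. Compound 3 is therefore estimated at 800 nM in this assay, within a range of 300 nM to 2500 nM.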

Compound 3, half-maximal inhibitory concentration: 700 nM
For compound 3 the middle estimate is 1.1-fold (0.06 log units) above the measured one, within the range that was stated.
By their numbers in this assay, from the lowest: compounds 1, 3 and 2 (each within the scatter of the next).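

Methyl in place of isopropyl on a saturated chain carbon bound to an amide-type nitrogen and a triple-bonded carbon gives a 1.4-fold higher number from compound 1 to compound 3 (0.15 log units; within the scatter) in this assay and so stays within the scatter. Among the compounds shown here, this is the first comparison in which only this group differs; compound 2 could not give it, as it also carries a different amide side. With that side held the same, methyl and isopropyl at this place cannot be told apart on these numbers, and nothing at hand offers an explanation for this result.

On these data alone, whether a hydrogen, a tert-butyl group or a longer chain ending in an amine at this place would separate from these two groups remains open. As far as these compounds go, it is also open whether methyl and isopropyl would stay indistinguishable with a different amide side.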